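The compounds below may be only part of what the source reports. "The series", "measured", "known", "first", "only" and "open" are said of these compounds alone.

Working notes on the series. Compound 1 `COc1ccc(-c2ccc(-c3ccc(C(=N)N)cc3)s2)cc1` and compound 2 `COc1cc(OC)cc(-c2ccc(-c3ccc(C(=N)N)c(F)c3)s2)c1` share a core and have both been run in a functional assay on HT-29 cells (Homo sapiens) for inhibition, read by sulforhodamine B assay, with a stated time of 48 h; on this read-out higher numbers stand for weaker inhibition of growth and lower numbers for stronger inhibition of growth. In this assay compound 1 gives 196 nM and compound 2 gives 267 nM. Of the two numbers, compound 1 holds the lower one, with compound 2 the nearest at a gap that lies within the usual scatter; the two compounds differ in more than one place, so nothing beyond the two values themselves is taken from that pair.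

Compound 3 `COc1ccc(-c2ccc(-c3ccc(C(=N)N)c(F)c3)s2)cc1` has not yet been measured. It differs from compound 1 in one place: fluoro in place of hydrogen on an aromatic carbon. Within the data shown here, no single-change step between measured compounds is available for this change. Given that compound 2, which also carries a fluoro, returns 267 nM within the scatter of compound 1, the step from compound 1 to compound 3 is expected to be a 1.1-fold higher number from compound 1 to compound 3 (0.05 log units; within the scatter), none beyond the scatter. Compound 3 is therefore estimated at 220 nM, with a range from 110 nM to 450 nM.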

Compound 3, concentration for 50% growth inhibition: 2790 nM
Compound 3: the middle estimate sits 13-fold (1.10 log units) below what was measured; measured number above the stated range.
By their numbers in this assay, from the lowest: compounds 1 and 2 (each within the scatter of the next); then compound 3.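

In this assay, among these compounds, fluoro in place of hydrogen on an aromatic carbon, ortho to a group of 3 heavy atoms, is the first single-change step (a 14-fold higher number from compound 1 to compound 3 (1.15 log units; beyond the scatter)). This position on the core of compound 1 is therefore sensitive to the change, and a fluoro here is not a neutral replacement for hydrogen. Compound 2 has no hydrogen counterpart among the compounds shown, so the effect of its fluoro cannot be read on its own.

No measurement at hand bears on the reason for this step.

Still open, going by these compounds, is whether the loss is specific to fluoro or also follows from other groups on this carbon, such as chloro, methyl or hydroxyl. Also open, on these data alone, is whether the step would be of similar size with the two methoxy groups of compound 2.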